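Turning a drawn double bond from E to Z

The source may report more compounds than this note shows. Statements on the series, on what has been measured and on what is new or still open speak of the compounds shown alone.

Measured compounds:
compound 1 `CC(=O)OC[C@H]1O[C@@H](n2cc(CN3C(=O)/C(=C\c4ccccc4)c4ccccc43)nn2)[C@H](OC(C)=O)[C@@H](OC(C)=O)[C@@H]1OC(C)=O` — 17900 nM
compound 2 `CCC/C=C1/C(=O)N(Cc2cn([C@@H]3O[C@H](COC(C)=O)[C@@H](OC(C)=O)[C@H](OC(C)=O)[C@H]3OC(C)=O)nn2)c2ccccc21` — 24100 nM

In a functional assay on A549 cells (Homo sapiens) for cytotoxicity, read by sulforhodamine B assay, with a stated time of 48 h (a lower number here means a stronger inhibitor, a higher number a weaker inhibitor), compound 1 gives 17900 nM and compound 2 gives 24100 nM. Compound 2 carries the higher of the two numbers, yet its nearest neighbour, compound 1, sits lower by an amount that stays within the usual scatter of this assay, so no order between the two can be read. Compound 3 `CCC/C=C1\C(=O)N(Cc2cn([C@@H]3O[C@H](COC(C)=O)[C@@H](OC(C)=O)[C@H](OC(C)=O)[C@H]3OC(C)=O)nn2)c2ccccc21` is the unmeasured partner of compound 2: the two compounds have the same atoms and bonds and differ only in configuration as drawn: 1 of 6 stereo elements differ; a double bond is drawn E in compound 2 and Z in compound 3. For the measured compounds named here, no step between two measured compounds covers such a change of drawn geometry, so there is nothing to lean on, and the account expects no step in this assay beyond the scatter when the E drawing of compound 2 becomes the Z drawing of compound 3. Compound 3 is therefore estimated at 22000 nM, with a range from 8000 nM to 60000 nM. Against compound 2 the expected step is a 1.1-fold lower number from compound 2 to compound 3 (0.04 log units; within the scatter).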

Compound 3, half-maximal inhibitory concentration: 40400 nM
Beside the measured number, compound 3's estimate is 1.8-fold (0.26 log units) below it, and the stated range covers the measured number.
By their numbers in this assay, from the lowest: compounds 1, 2 and 3 (each within the scatter of the next, the first and the last beyond it).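

In this assay, redrawing the double bond from E to Z gives a 1.7-fold higher number from compound 2 to compound 3 (0.22 log units; within the scatter), so this first measured change of geometry at this position stays within the scatter, and no order can be read between the two compounds. Any difference between them could only lie in the drawn geometry: the fact that compounds 2 and 3 differ only in the configuration as drawn Propyl in place of phenyl on a double-bonded chain carbon bound to a double-bonded ring carbon gives a 2.3-fold higher number from compound 1 to compound 3 (0.35 log units; beyond the scatter), the only step here beyond the scatter, and a modest one.

The compounds shown leave open whether the same change of geometry matters with phenyl on the double bond. They also leave open whether a longer chain, or an amine at the end of the propyl chain, would shift the number further at this position.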